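The source may hold more compounds than are shown below. What is called first, only, known or untested is meant among the compounds shown, and "the series" means these compounds.

Working notes on the series. In an assay on cells for displacement of a labelled ligand from corticotropin-releasing factor receptor 1 (Homo sapiens), with a stated time of 100 min (on this read-out higher numbers stand for weaker inhibition and lower numbers for stronger inhibition), compound 1 `Cc1cc(C)c(-n2c(Cl)cn3c(CN(CCC(F)(F)F)CC4CC4)c(C(F)(F)F)nc23)c(C)c1` gives 16 nM, and compound 2 `Cc1cc(C)c(-n2c(Cl)cn3c(CN(CCC4CC4)CCC(F)(F)F)c(C(F)(F)F)nc23)c(C)c1` gives 110 nM. Among the compounds with values here, compound 2 therefore carries the higher of the two numbers so far; the one change measured, a 6.9-fold higher number from compound 1 to compound 2 (0.84 log units; beyond the scatter), is the step to it. Compound 3 `Cc1cc(C)c(-n2c(Cl)cn3c(CN(CCC(F)(F)F)Cc4cccc(F)c4)c(C(F)(F)F)nc23)c(C)c1` has not been measured in this assay. It differs from compound 2 in one place: 3-fluorophenyl in place of cyclopropylmethyl on a saturated chain carbon bound to an amine nitrogen. Within the data shown here, only the step from compound 1 to compound 2 touches the same position, and it altered a chain length rather than exchanging a three-membered ring for an aromatic ring, so its size is a loose guide only. A change of this kind could move the number in either direction; a shift back toward the value of compound 1 is expected rather than a further rise. The expected step is a 2.8-fold lower number from compound 2 to compound 3 (0.44 log units; beyond the scatter). For compound 3 the estimate in this assay is 40 nM, within a range from 10 nM to 160 nM.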

Compound 3, inhibition constant: 49 nM
For compound 3 the middle estimate is 1.2-fold (0.09 log units) below the measured one; measured number inside the range.
By their numbers in this assay, from the lowest: compound 1; then compound 3; then compound 2.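

In this assay, an aromatic ring is accepted at this position: going from 2-cyclopropylethyl to 3-fluorobenzyl gives a 2.2-fold lower number from compound 2 to compound 3 (0.35 log units; beyond the scatter), so the number does not rise steadily as the group grows. The recovery is only partial, with a 3.1-fold higher number from compound 1 to compound 3 (0.49 log units; beyond the scatter), which leaves compound 1 with the lowest number of the three and compound 2 with the highest. No measurement on hand accounts for either shift.

The compounds shown do not separate the contribution of the aromatic ring from that of its fluorine, and a plain benzyl group would be needed to do so. From the compounds shown here alone, whether a ring nitrogen is tolerated here, as in a pyridylmethyl group, also remains open.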